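Notes on moving the chlorine within the chlorophenyl group

The compounds below may be only part of what the source reports. "The series", "measured", "known", "first", "only" and "open" are said of these compounds alone.

Measured compounds:
compound 1 `Oc1ccc(-c2cc(-c3ccc(Cl)cc3)nc(-c3cccnc3)c2)cc1`: 18.8%
compound 2 `Oc1ccc(-c2cc(-c3ccccc3)nc(-c3ccc(Cl)cc3)c2)cc1`: 68%
compound 3 `Oc1ccc(-c2cc(-c3ccc(Cl)cc3)nc(-c3ccccn3)c2)cc1`: 12.7%
compound 4 `Oc1ccc(-c2cc(-c3cccnc3)nc(-c3ccccc3Cl)c2)cc1`: not yet measured

In an assay on isolated protein for inhibition of DNA topoisomerase 1 (Homo sapiens), with a stated time of 30 min, tested at 100 uM (on this read-out higher numbers stand for a stronger effect at the one concentration tested and lower numbers for a weaker effect), compound 1 gives 18.8%, the second highest of the three numbers. Its nearest neighbour is compound 3, with a number 6.1 percentage points lower from compound 1 to compound 3 (within the scatter), so the two cannot be ordered. Among the compounds with values here, the only large change seen so far is a number 49.2 percentage points higher from compound 1 to compound 2 (beyond the scatter), and the matching a number 55.3 percentage points lower from compound 2 to compound 3 (beyond the scatter); both concern the pyridin-3-yl group of compound 1 being exchanged for phenyl or pyridin-2-yl.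

Compound 4 differs from compound 1 at another place: 2-chlorophenyl in place of 4-chlorophenyl on an aromatic carbon. Within the data shown here, no measured step touches the chlorophenyl group, so none of the three steps bears directly on this change. The series gives no hint that this position is as sensitive as the pyridin-3-yl position, but it also gives no hint against it. In the absence of a relevant step, a change staying within the scatter is the most defensible expectation, with the range widened to allow for an unseen effect.

For compound 4 in this assay the expected value is therefore 20%, with a range from 5% to 45%; this estimate means a step of a number 1.2 percentage points higher from compound 1 to compound 4 (within the scatter).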

Compound 4, a percentage reported as inhibition, at one concentration (the size of the read-out at that concentration, not a potency): 0.9%
For compound 4 the middle estimate is 19.1 percentage points above the measured one; the measured number lies below the stated range.
By their numbers in this assay, from the lowest: compound 4; then compounds 3 and 1 (each within the scatter of the next); then compound 2.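

The chlorophenyl group is not a silent place in the series: in this assay, a number 17.9 percentage points lower from compound 1 to compound 4 (beyond the scatter), although the group that enters keeps the same heavy atoms and the same aromatic ring as the one that leaves. Where the chlorine sits on this ring, at the carbon next to the ring nitrogen of the core, therefore changes the read-out on its own, and the pyridin-3-yl position is no longer the only place where a step beyond the scatter is seen. The data shown offer no measured basis for explaining this shift.

As far as these compounds go, it remains open whether the step reflects the gain of the 2-chlorophenyl group or the loss of the 4-chlorophenyl group, a question that a 3-chlorophenyl, an unsubstituted phenyl or a 4-methoxyphenyl group at this place would help to separate. Also open, from the compounds shown here alone, is whether the same move of the chlorine would lower the number in compound 2 , which stands at 68% in this assay and carries a phenyl group in place of the pyridin-3-yl group.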